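Kinetic Solubility Across Two Amide Variants of a Shared Core

The compounds below may be only part of what the source reports. "The series", "measured", "known", "first", "only" and "open" are said of these compounds alone.

Within the data shown here, compound 2 `O=C(Nc1cccc(-c2nc3ccccc3s2)c1)c1cccnc1Cl` is one of two compounds measured in a physicochemical assay for solubility, in phosphate buffer, measured as kinetic solubility, with a stated time of 18 h, at pH 7.4; on this read-out lower numbers stand for lower solubility and higher numbers for higher solubility. Compound 2 gives 520 nM, the top of the two numbers shown, though only by a gap within the scatter: compound 1 `C=C(C)C(=O)Nc1cccc(-c2nc3ccccc3s2)c1` gives 420 nM, and the step of a 1.2-fold higher number from compound 1 to compound 2 (0.09 log units; within the scatter) does not separate the two. Compound 3 `O=C(Nc1cccc(-c2nc3ccccc3s2)c1)c1cnc(Cl)s1` has not been measured. It differs from compound 2 in one place (2-chloro-1,3-thiazol-5-yl in place of 2-chloropyridin-3-yl on a carbonyl carbon), a change on the same carbonyl carbon that was varied between compound 1 and compound 2. Among the measured compounds shown here, the only measured step that bears on this change is a 1.2-fold higher number from compound 1 to compound 2 (0.09 log units; within the scatter), and that replacement of the whole group on the carbonyl carbon moved the number no further than repeated measurements do. With no other guidance from the measured compounds, the step of a 1.0-fold lower number from compound 2 to compound 3 (0.02 log units; within the scatter) is expected to stay within the scatter as well. Compound 3 is therefore estimated to give 500 nM in this assay, with a range from 230 nM to 1100 nM.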

Compound 3, solubility: 940 nM
For compound 3 the middle estimate is 1.9-fold (0.27 log units) below the measured one; measured number inside the range.
By their numbers in this assay, from the lowest: compounds 1, 2 and 3 (each within the scatter of the next, the first and the last beyond it).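

Among these compounds, on this carbonyl carbon, a replacement of the group now moves the number beyond the scatter in this assay: a 2.2-fold higher number from compound 1 to compound 3 (0.35 log units; beyond the scatter), a modest step and the only one among the three compounds to go that far. Among the compounds shown here, the exchange of 2-chloropyridin-3-yl for 2-chloro-1,3-thiazol-5-yl does not separate the two chlorinated aromatic groups, since a 1.8-fold higher number from compound 2 to compound 3 (0.26 log units; within the scatter), so the change from a six-membered to a five-membered ring cannot be read as a real difference on its own, and only the pair of compound 1 and compound 3 stands apart. No measured evidence accounts for the gap between compound 1 and compound 3.

Going by these compounds, how the number responds on this carbonyl carbon to a quite different kind of group, such as a morpholine, a carboxylic acid or a longer alkyl chain, remains open. Also open, on these data alone, is whether the gap holds when the chlorine on the 2-chloro-1,3-thiazol-5-yl group gives way to a methyl group or an amine, and whether a change elsewhere on the shared core would move the number further than any change seen here.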